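This account rests on a few compounds, and the source may have more. Where it says the series, first, only, none or still open, it means among the compounds named here.

Compound 3 `CC[C@@H](C)Nc1nc(Cl)nc(N[C@@H](C)c2ccccc2)n1` gives 7410 nM in an ADME assay on the whole organism for inhibition, with Echinochloa crus-galli var. formosensis as the target, with a stated time of 4 days (a higher number here means a weaker inhibitor, a lower number a stronger inhibitor), the second highest of the three numbers shown: compound 2 `CCNc1nc(Cl)nc(N[C@H](C)c2ccccc2)n1` gives 2690 nM and compound 1 `CNc1nc(Cl)nc(N[C@@H](C)c2ccccc2)n1` gives 26900 nM. Compound 4 `CC(C)N(c1nc(Cl)nc(N[C@@H](C)c2ccccc2)n1)C(C)C` differs from compound 3 by diisopropylamino in place of (sec-butyl)amino on an aromatic carbon. For the measured compounds named here, the only measured step at this point is a 3.6-fold lower number from compound 1 to compound 3 (0.56 log units; beyond the scatter), sec-butyl in place of methyl on a nitrogen on an aromatic ring, which went to a lower number. Going by the values given here, no measured pair removes the hydrogen-bond donor or brings in diisopropylamino, so that part of the change has no precedent here. Compound 4 is therefore expected to show only a 1.2-fold higher number from compound 3 to compound 4 (0.08 log units; within the scatter), with wide uncertainty. The estimate for compound 4 is 9000 nM, with a range from 2500 nM to 40000 nM.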

Compound 4, half-maximal inhibitory concentration: 110 nM
Compound 4: the middle estimate sits 82-fold (1.91 log units) above what was measured; measured number outside the range, below it.
By their numbers in this assay, from the lowest: compound 4; then compound 2; then compound 3; then compound 1.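

In this assay, the change to a fully substituted nitrogen on an aromatic carbon between two ring nitrogen atoms gives a 67-fold lower number from compound 3 to compound 4 (1.83 log units; beyond the scatter) and, measured from the methylamino compound, a 240-fold lower number from compound 1 to compound 4 (2.39 log units; beyond the scatter). For the compounds shown here, both steps are large, whereas a 3.6-fold lower number from compound 1 to compound 3 (0.56 log units; beyond the scatter) was only modest, so this position can move the number much further than the earlier compounds showed. Nothing here gives a reason for the step. The compounds shown leave open whether the lost amino hydrogen or the diisopropylamino group itself carries the step, since both change together. Diethylamino or N-methyl-sec-butylamino at this place would bear on that question.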